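From Ethyl to Isopropyl: A Step Within the Scatter

The source may hold more compounds than are shown below. What is called first, only, known or untested is meant among the compounds shown, and "the series" means these compounds.

Of the compounds shown here, two have been measured in an ADME assay on the whole organism with Oryza sativa as the target, tested at 0.1 uM; on this read-out lower numbers stand for a stronger effect and higher numbers for a weaker effect at the one concentration tested. Compound 1 `Cc1cccc(NC(=O)N[C@H](C)c2ccccc2)c1` gives 100% in this assay, and compound 2 `CCc1cccc(NC(=O)N[C@H](C)c2ccccc2)c1` gives 97%. Among the measured compounds shown here, the only step measured so far, a number 3 percentage points lower from compound 1 to compound 2 (within the scatter), describes methyl in place of hydrogen on a saturated chain carbon bound to an aromatic carbon. On the numbers shown, compound 2 stands with its nearest neighbour, compound 1, inside the usual scatter, so the two compounds cannot be separated on this read-out.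

Compound 3 `CC(C)c1cccc(NC(=O)N[C@H](C)c2ccccc2)c1` has not been measured. It differs from compound 2 by methyl in place of hydrogen on a saturated chain carbon bound to an aromatic carbon and a saturated chain carbon, a change that, cut one bond further out, reads ethyl to isopropyl. For the measured compounds named here, the single measured step bears on this change because a number 3 percentage points lower from compound 1 to compound 2 (within the scatter) added the same group at a saturated chain carbon bound to an aromatic carbon and produced nothing beyond the scatter. The step to compound 3 is therefore expected to be a number 1 percentage points lower from compound 2 to compound 3 (within the scatter), with no movement beyond the scatter in either direction. Compound 3 is estimated to give 96%, within a range from 86% to 100%.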

Compound 3, a percentage reported as activity, at one concentration (the size of the read-out at that concentration, not a potency): 74%
Estimate against measurement, compound 3: 22 percentage points above, outside the stated range (below it).
By their numbers in this assay, from the lowest: compound 3; then compounds 2 and 1 (each within the scatter of the next).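

In this assay, a methyl in place of hydrogen on a saturated chain carbon bound to an aromatic carbon and a saturated chain carbon gives a number 23 percentage points lower from compound 2 to compound 3 (beyond the scatter), whereas the earlier methyl addition gave a number 3 percentage points lower from compound 1 to compound 2 (within the scatter), so adding the same group does not have the same outcome at each stage of this series. Taken as a whole, isopropyl in place of methyl on an aromatic carbon gives a number 26 percentage points lower from compound 1 to compound 3 (beyond the scatter), which sets compound 3 apart from both compound 1 and compound 2, while those two remain within the scatter of each other. Nothing available explains why isopropyl separates from ethyl and methyl on this read-out.

The compounds shown leave open whether the lower number continues with a tert-butyl group or a cyclopropyl ring, or whether it is specific to isopropyl. They also leave open how a longer chain such as n-propyl would read, and whether a methoxy group or an amine at the same place would fall with compound 3 or stay with compound 1 and compound 2.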